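Adding a chloro group to a benzyl side chain, second time round

The source may hold more compounds than are shown below. What is called first, only, known or untested is meant among the compounds shown, and "the series" means these compounds.

Measured compounds:
- compound 1, `Cc1ccc(S(=O)(=O)Nc2nnc(SCc3ccccc3)s2)cc1`: 61%
- compound 2, `Cc1ccc(S(=O)(=O)Nc2nnc(SCc3ccc(Cl)cc3)s2)cc1`: 68%
- compound 3, `Cc1cc(C)c(S(=O)(=O)Nc2nnc(SCc3ccccc3)s2)c(C)c1`: 57%

These three compounds were tested in a functional assay on MCF7 cells (Homo sapiens) for cytotoxicity, tested at 250 uM; on this read-out lower numbers stand for a stronger effect and higher numbers for a weaker effect at the one concentration tested. Compound 1 and compound 2 share a core and differ in one place: chloro in place of hydrogen on an aromatic carbon. This step, a number 7 percentage points higher from compound 1 to compound 2 (within the scatter), is too small to be read as a real change. Compound 3 has a different core; how it differs from compound 1 is not broken down here. In this assay compound 3 gives 57%, which is close to what compound 1 gives and a little apart from compound 2.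

Compound 4, `Cc1cc(C)c(S(=O)(=O)Nc2nnc(SCc3ccc(Cl)cc3)s2)c(C)c1`, has not yet been measured. It is made from compound 3 by the same change that turns compound 1 into compound 2: chloro in place of hydrogen on an aromatic carbon. Because the earlier step, a number 7 percentage points higher from compound 1 to compound 2 (within the scatter), stayed within the scatter, the step from compound 3 to compound 4 is expected to be small as well, a number 7 percentage points higher from compound 3 to compound 4 (within the scatter). Compound 4 is therefore estimated to give about 64% in this assay, most likely between 52% and 76%.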

Compound 4, a percentage reported as activity, at one concentration (the size of the read-out at that concentration, not a potency): 61%
For compound 4 the middle estimate is 3 percentage points above the measured one, and the stated range covers the measured number.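

In this assay, chloro in place of hydrogen on the benzyl group gives a number 4 percentage points higher from compound 3 to compound 4 (within the scatter), and the change reads the same on both cores: the same change on two cores in this assay, a number 7 percentage points higher (within the scatter) from compound 1 to compound 2 and a number 4 percentage points higher (within the scatter) from compound 3 to compound 4, 3 percentage points apart, within the scatter of two such steps.
Going the other way round the square, 2,4,6-trimethylphenyl in place of 4-methylphenyl on the sulfonyl sulfur gives a number 7 percentage points lower from compound 2 to compound 4 (within the scatter), so that swap also leaves the number without a readable change. Within the data shown here, this shows only that the chloro step stays small on these two cores; with steps this small, it does not show that chloro has any real effect, and two cores at a single concentration say nothing about how the change would behave on further cores.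

The compounds shown leave open whether a different group in place of the chloro, such as an amine or a carboxylic acid, would move the number beyond the scatter. They also leave open what a longer chain in place of the benzyl group would do.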